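This account rests on a few compounds, and the source may have more. Where it says the series, first, only, none or still open, it means among the compounds named here.

In a functional assay on MCF7 cells (Homo sapiens) for antiproliferative activity, read by MTT assay, with a stated time of 72 h (a lower number here means a stronger inhibitor, a higher number a weaker inhibitor), compound 1 `CCOc1ccc(-c2ncnn2-c2cc(OC)c(OC)c(OC)c2)cc1` gives 50 nM and compound 2 `COc1cc(-n2ncnc2-c2ccc(OC(C)C)cc2)cc(OC)c1OC` gives 610 nM as the higher of the two numbers. Compound 3 `COc1cc(-n2ncnc2-c2ccc(F)cc2)cc(OC)c1OC` keeps the shared core and differs from compound 2 in one group. The change is fluoro in place of isopropoxy on an aromatic carbon (fluoro in place of isopropoxy on an aromatic carbon, para to a large group). Among the measured compounds shown here, one measured step bears on this group: a 12-fold higher number from compound 1 to compound 2 (1.09 log units; beyond the scatter) comes with methyl in place of hydrogen on a saturated chain carbon bound to an oxygen, and it is large. Small edits to this group can thus move the number far in this assay but no measured compound carries fluoro, so the direction remains open. A step within the scatter is expected, with a wide margin either way. The estimated step is a 1.2-fold lower number from compound 2 to compound 3 (0.09 log units; within the scatter) for this change. Compound 3 is expected at 500 nM with 120 nM to 2500 nM as its estimated range.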

Compound 3, half-maximal inhibitory concentration: > 10000 nM
Compound 3: a limit, no number; the forecaster's own chance of this, stated with the estimate: 8%; at least 20-fold (1.30 log units) between middle value and limit.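

Compound 3 stands at a limit, not a number, in this assay: the limit of > 10000 nM in this assay, at which 1 of the 3 values shown sits.

The change to fluoro brings an at least 16-fold higher number from compound 2 to compound 3 (1.21 log units; beyond the scatter) and an at least 200-fold higher number from compound 1 to compound 3 (2.30 log units; beyond the scatter). Until now this position, para to a large group, had been probed only by comparing ethoxy with isopropoxy, whereas these steps show that replacing either alkoxy group with fluoro costs at least as much as the earlier change between the two, and likely more. Among the three compounds, only those carrying an alkoxy group here give a number.

Open, as far as these compounds go, is whether the oxygen-linked chain is what matters or whether fluoro itself drives the loss. A methoxy group, an amine or a longer chain such as butoxy at this position would help separate these readings.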